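This account rests on a few compounds, and the source may have more. Where it says the series, first, only, none or still open, it means among the compounds named here.

Working notes on the series, step from compound 2 to compound 3.

Within the data shown here, compound 2 `CN1CCCCC1CNc1nc2c(c(Nc3ccc(C(F)(F)F)cc3)n1)CCN(c1ncccc1C(F)(F)F)CC2` is the weaker of the two compounds measured so far in a functional assay on HEK293 cells for antagonist activity at transient receptor potential cation channel subfamily V member 1 (Rattus norvegicus), read by FLIPR and calcium flux; on this read-out higher numbers stand for weaker inhibition and lower numbers for stronger inhibition: compound 2 gives 2280 nM, while compound 1 `CCC(CC)N1CCN(c2nc3c(c(Nc4ccc(C(F)(F)F)cc4)n2)CCN(c2ncccc2C(F)(F)F)CC3)CC1` gives 185 nM. Among the measured compounds shown here, the single step between them, a 12-fold higher number from compound 1 to compound 2 (1.09 log units; beyond the scatter), is the only measured step and is large.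

Compound 3 `CNC1CCN(c2nc3c(c(Nc4ccc(C(F)(F)F)cc4)n2)CCN(c2ncccc2C(F)(F)F)CC3)C1` is obtained from compound 2 by the change (3-(methylamino)pyrrolidin-1-yl in place of ((1-methylpiperidin-2-yl)methyl)amino on an aromatic carbon). The change brings back a ring on that aromatic carbon, as in compound 1 with its 4-(pentan-3-yl)piperazin-1-yl group, whereas compound 2 carries its six-membered ring on a methylamino chain. The measured step from compound 1 to compound 2 bears on this: going from a ring on the aromatic carbon to a chain-linked ring cost a large amount. For compound 3 a partial recovery toward the number of compound 1 is therefore expected, and the estimated step of a 4.1-fold lower number from compound 2 to compound 3 (0.62 log units; beyond the scatter) is a lower number beyond the scatter. The estimate for compound 3 in this assay is 550 nM, with a range from 150 nM to 1800 nM.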

Compound 3, half-maximal inhibitory concentration in the transient receptor potential cation channel subfamily V member 1 assay: > 5000 nM
Compound 3: only a limit was reported; the forecaster's own chance of this, stated with the estimate: 5%; at least 9.0-fold (0.95 log units) between middle value and limit.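

In the transient receptor potential cation channel subfamily V member 1 assay, compound 3 gives > 5000 nM, which is reported only as a limit, not as a number: the limit of > 5000 nM in the transient receptor potential cation channel subfamily V member 1 assay, at which 1 of the 3 values shown sits.

Even read as a limit, the result shows that a ring attached through its nitrogen to the aromatic carbon between two ring nitrogen atoms does not by itself bring back the number of compound 1, since the transient receptor potential cation channel subfamily V member 1 assay gives an at least 2.1-fold higher number from compound 2 to compound 3 (0.34 log units; beyond the scatter) and an at least 27-fold higher number from compound 1 to compound 3 (1.43 log units; beyond the scatter). In a physicochemical assay for solubility, in simulated intestinal fluid, measured as thermodynamic solubility, at pH 6.8 (a higher number here means a more soluble compound, a lower number a less soluble compound), compound 2 gives 254 ug/mL and compound 3 gives 233 ug/mL. In the physicochemical assay, the same swap gives a 1.1-fold lower number from compound 2 to compound 3 (0.04 log units; within the scatter), so compound 2 and compound 3 do not separate on solubility, and the gap in inhibition appears without a matching gap on that read-out.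

The compounds shown do not separate the contribution of the five-membered ring from that of the methylamino group on it or of the pentan-3-yl group, and how far compound 3 lies past its limit stays unknown. A 4-methylpiperazin-1-yl group or an unsubstituted pyrrolidin-1-yl group at this position would bear on these questions.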